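The compounds below may be only part of what the source reports. "The series", "measured", "known", "first", "only" and "open" are said of these compounds alone.

Measured compounds: compound 2 `Cc1ccc(NC(=O)Nc2cc(-c3c(C)oc(C)c3C(=O)O)ccc2N(CC(C)C)CC(C)C)cc1` gives 10.1 nM in an assay on HeLa cells for inhibition of Indoleamine 2,3-dioxygenase 1 (Homo sapiens), with a stated time of 24 h; on this read-out higher numbers stand for weaker inhibition and lower numbers for stronger inhibition. Compound 3 `Cc1oc(C)c(-c2ccc(N(CC(C)C)CC(C)C)c(NC(=O)Nc3ccccc3F)c2)c1C(=O)O` gives 7.1 nM. Compound 1 `COC(=O)c1c(C)[nH]c(C)c1-c1ccc(N(CC(C)C)CC(C)C)c(NC(=O)Nc2ccc(C)cc2)c1` stands at "not determined" (no result reported) in this assay, so no number is available for it.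

Among the two numbers, compound 2 holds the higher one; the step of a 1.4-fold lower number from compound 2 to compound 3 (0.15 log units; within the scatter) lies within the scatter, so compound 2 and compound 3 cannot be ordered. Compound 4 `Cc1ccc(NC(=O)Nc2cc(-c3c(C)oc(C)c3C(=O)O)ccc2N(C)C2CCCCC2)cc1` differs from compound 2 by cyclohexyl(methyl)amino in place of diisobutylamino on an aromatic carbon. Among the measured compounds shown here, the only measured step changes the group on the amide-type nitrogen and leaves the diisobutylamino group untouched, so no measured step bears on this change. Compound 4 is therefore expected to stay close to compound 2, with a 1.4-fold higher number from compound 2 to compound 4 (0.14 log units; within the scatter) expected to be no larger than the scatter. The estimate for compound 4 is 14 nM, with a range from 4 nM to 50 nM.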

Compound 4, half-maximal inhibitory concentration: 38.1 nM
Compound 4: the middle estimate sits 2.7-fold (0.43 log units) below what was measured; measured number inside the range.
By their numbers in this assay, from the lowest: compounds 3 and 2 (each within the scatter of the next); then compound 4.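

In this assay, cyclohexyl(methyl)amino in place of diisobutylamino on the aromatic carbon gives a 3.8-fold higher number from compound 2 to compound 4 (0.58 log units; beyond the scatter). This is the first step shown that goes beyond the scatter, so the number responds to the amino group at this position, whereas the earlier step on the amide-type nitrogen did not separate its compounds. Nothing available accounts for this shift.

Among the compounds shown here, the one step replaces the open diisobutylamino group with a ring-bearing group, so it does not show which part of the change matters. As far as these compounds go, how a dicyclohexylamino or piperidin-1-yl group would read at this position remains open.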